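The source may report more compounds than this note shows. Statements on the series, on what has been measured and on what is new or still open speak of the compounds shown alone.

Measured in a functional assay on COLO 320 cells (Homo sapiens) for cytotoxicity, read by MTT assay, with a stated time of 24 h; a higher number here means a weaker inhibitor, a lower number a stronger inhibitor:
- compound 1 `C[Se]C(=O)c1ccc(C(=O)[Se]C)s1`: > 100000 nM (a limit of the assay, not a number)
- compound 2 `CC(C)(C)C(=O)C[Se]C(=O)c1ccc(Cl)cc1`: 960 nM
- compound 3 `CC(=O)C[Se]C(=O)c1ccc(Cl)cc1`: 550 nM

Not yet measured: compound 4 `COC(=O)C[Se]C(=O)c1ccc(Cl)cc1`.

For the measured compounds named here, compound 3 gives 550 nM and sits within the scatter of compound 2, the only other compound with a number. Going by the values given here, compound 1 stands at a limit and offers no step to work from.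

The change from compound 3 to compound 4 is methoxy in place of methyl on a carbonyl carbon, which turns acetyl into methoxycarbonyl. Among the compounds with values here, the only measured step at this carbonyl carbon is a 1.7-fold lower number from compound 2 to compound 3 (0.24 log units; within the scatter). That one exchange is slim evidence, and it involves no oxygen-bearing group, so it cannot show how methoxy will behave. It does show that a large change of the group at this position left the number within the scatter.

In this assay, no step beyond the scatter is therefore the central expectation, with no firm direction, though the uncertainty is wider than for a repeat measurement. The expected step is a 1.3-fold higher number from compound 3 to compound 4 (0.10 log units; within the scatter). For compound 4 the estimated value is 700 nM, with an expected range of 200 nM to 2500 nM.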

Compound 4, half-maximal inhibitory concentration: > 100000 nM
Compound 4: no number, only a limit (the forecaster's own chance of this, stated with the estimate: 3%); middle value at least 140-fold (2.15 log units) from the limit.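

In this assay, methoxy in place of methyl on a carbonyl carbon gives an at least 180-fold higher number from compound 3 to compound 4 (2.25 log units; beyond the scatter), and methoxy in place of tert-butyl at the same carbon gives an at least 100-fold higher number from compound 2 to compound 4 (2.01 log units; beyond the scatter). The earlier exchange of tert-butyl for methyl, a 1.7-fold lower number from compound 2 to compound 3 (0.24 log units; within the scatter), gave no sign of such a step, so this position does not accept every group, and tolerance of two very different carbon-linked groups did not carry over to methoxy. Compound 4 gives only a limit and not a number, so both new steps mark a minimum and their full size cannot be read: the limit of > 100000 nM in this assay, at which 2 of the 4 values shown sit.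

With only methoxy as an oxygen-linked group here, the compounds shown cannot tell whether the methoxy oxygen or the methoxycarbonyl group as a whole goes with this result, and a dimethylamino group, a hydroxyl group or an ethyl group on the same carbonyl carbon would help separate these readings. Whether a longer ester such as ethoxycarbonyl behaves like compound 4 also stays open, and nothing shown gives a cause for the step.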